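Swapping the methoxy-bearing ring on a thiazole core

The source may hold more compounds than are shown below. What is called first, only, known or untested is meant among the compounds shown, and "the series" means these compounds.

Three compounds share a thiazole-like core carrying a trifluoromethyl group and a methyl-substituted piperazine amide, and all were measured in an assay on blood for inhibition of C-X-C chemokine receptor type 3 (Homo sapiens), with a stated time of 30 min; a higher number here means a weaker inhibitor, a lower number a stronger inhibitor. Compound 1, `C[C@@H]1CN(c2scnc2-c2nc3ccccc3[nH]2)CCN1C(=O)Cn1cnc2cccnc21`, gives 554 nM. Compound 2, `COc1ncc(-c2nc(C(F)(F)F)sc2N2CCN(C(=O)Cn3cnc4cccnc43)[C@H](C)C2)cn1`, gives 158 nM. Compound 3, `COc1ncc(-c2nc(C(F)(F)F)sc2N2CCN(C(=O)Cn3nc(C)nc3C)[C@H](C)C2)cn1`, gives 1040 nM. Compound 3 therefore holds the highest number of the three, though its gap to compound 1 lies within the scatter, while its gap to compound 2 is real: a 6.6-fold higher number from compound 2 to compound 3 (0.82 log units; beyond the scatter).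

Compound 4, `COc1ccc(-c2nc(C(F)(F)F)sc2N2CCN(C(=O)Cn3nc(C)nc3C)[C@H](C)C2)cn1`, has not yet been measured. It differs from compound 3 only at the ring attached to the core: 6-methoxypyridin-3-yl in place of 2-methoxypyrimidin-5-yl on an aromatic carbon. Among the measured compounds shown here, no measured pair changes this ring; the one step that is known, from compound 2 to compound 3, alters the group on the saturated chain carbon bound to the carbonyl carbon, so it says nothing direct about the present change. With no guidance from the data, the safest expectation is a step of no more than the usual scatter. Compound 4 is thus expected to give 1000 nM, with a range from 400 nM to 2500 nM. The expected step is a 1.0-fold lower number from compound 3 to compound 4 (0.02 log units; within the scatter), which lies within the scatter.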

Compound 4, half-maximal inhibitory concentration: 1580 nM
Estimate against measurement, compound 4: 1.6-fold (0.20 log units) below; the measured number falls inside the stated range.
By their numbers in this assay, from the lowest: compound 2; then compounds 1, 3 and 4 (each within the scatter of the next, the first and the last beyond it).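

Among the compounds shown here, this is the first pair that changes the ring on the aromatic carbon of the shared core: in this assay, 6-methoxypyridin-3-yl in place of 2-methoxypyrimidin-5-yl gives a 1.5-fold higher number from compound 3 to compound 4 (0.18 log units; within the scatter). At this position, then, a six-membered aromatic ring with 1 hetero atom can replace one with 2 hetero atoms without a step beyond the scatter, at least when the methoxy group stays on the ring and the rest of the molecule stays as in compound 3. This is a single pair, so it marks no trend, and no measurement shown here bears on what lies behind the result.

On these data alone, it remains open whether the same ring exchange would also give a step within the scatter if the group of 9 heavy atoms from compound 2 stood on the saturated chain carbon, since that group goes with the lowest number of the set. Also open, as far as these compounds go, is how this aromatic carbon would respond to a ring with a different substituent, such as an amine or a carboxylic acid in place of the methoxy group.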